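Benzyloxy on the core: a second look at compound 3

A few compounds are considered here, and "the series" means these few. Any claim that something is new, unique, unknown or untested is made for them only; others in the source may bear on it.

Compound 1 `COc1ccc2occ(C(=O)NC3CCN(Cc4ccccc4)CC3)c(=O)c2c1`: 46300 nM
Compound 2 `O=C(NC1CCN(Cc2ccccc2)CC1)c1coc2ccc(OCc3ccccc3)cc2c1=O`: 35 nM
Compound 3 `O=C(NCCC1CCN(Cc2ccccc2)CC1)c1coc2ccccc2c1=O`: 35300 nM

In an assay on isolated protein for inhibition of Amine oxidase [flavin-containing] B (Homo sapiens), read by fluorescence and Amplex Red, with stated times of 15 min and 20 min (on this read-out lower numbers stand for stronger inhibition and higher numbers for weaker inhibition), compound 3 stands second highest of the three numbers, close to compound 1 and far from compound 2. Compound 4 `O=C(NCCC1CCN(Cc2ccccc2)CC1)c1coc2ccc(OCc3ccccc3)cc2c1=O` differs from compound 3 by benzyloxy in place of hydrogen on an aromatic carbon. Within the data shown here, the only measured step that bears on this is a 1300-fold lower number from compound 1 to compound 2 (3.12 log units; beyond the scatter), where the same ring position gained a phenyl on the chain carbon bound to the ring oxygen. A change of similar kind is therefore expected to give a large drop in this assay for compound 4, roughly a 590-fold lower number from compound 3 to compound 4 (2.77 log units; beyond the scatter). Compound 4 is thus estimated at 60 nM, with a range from 10 nM to 400 nM.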

Compound 4, half-maximal inhibitory concentration: 272 nM
Beside the measured number, compound 4's estimate is 4.5-fold (0.66 log units) below it, within the range that was stated.
By their numbers in this assay, from the lowest: compound 2; then compound 4; then compounds 3 and 1 (each within the scatter of the next).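

Benzyloxy on this aromatic carbon gives a 130-fold lower number from compound 3 to compound 4 (2.11 log units; beyond the scatter), so the large effect is not confined to the side chain of compound 2. This step also starts from hydrogen, whereas the earlier step started from a methoxy group, so the gain from benzyloxy does not depend on that earlier starting point. Nothing shown here explains why the number falls so far.

Going by these compounds, it remains open whether the whole benzyloxy group is needed at this carbon. A smaller ethoxy group, an amine or a longer phenylethoxy chain there could each test this.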